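Thiourea in place of the benzyl on the ring nitrogen

The compounds below may be only part of what the source reports. "The series", "measured", "known", "first", "only" and "open" are said of these compounds alone.

Of the compounds shown here, three with a shared core have been measured in a functional assay on MKN-74 cells (Homo sapiens) for antiproliferative activity, with a stated time of 24 h; on this read-out lower numbers stand for stronger inhibition and higher numbers for weaker inhibition. Compound 1 `N#Cc1ccccc1CN1CCc2c(sc(NC(=O)c3ccccc3Cl)c2C(N)=O)C1` gives 9500 nM, compound 2 `NC(=O)c1c(NC(=O)c2ccccc2Cl)sc2c1CCN(Cc1ccccc1F)C2` gives 12900 nM, and compound 3 `NC(=O)c1c(NC(=O)c2ccccc2Cl)sc2c1CCN(Cc1ccc(Cl)cc1)C2` gives 18700 nM. The steps of a 1.4-fold higher number from compound 1 to compound 2 (0.13 log units; within the scatter), a 2.0-fold higher number from compound 1 to compound 3 (0.29 log units; within the scatter) and a 1.4-fold higher number from compound 2 to compound 3 (0.16 log units; within the scatter) set compound 3 at the upper end of the three numbers, but every gap among them falls within the scatter, so the three are indistinguishable on this read-out.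

Compound 4 `NC(=O)c1c(NC(=O)c2ccccc2Cl)sc2c1CCN(C(=S)Nc1ccccc1)C2` is not yet measured. It differs from compound 3 in that (a group of 9 heavy atoms (7 carbon, 1 nitrogen, 1 sulfur; one six-membered aromatic ring of carbon only) in place of a group of 8 heavy atoms (7 carbon, 1 chlorine; one six-membered aromatic ring of carbon only), on an amine nitrogen in a ring). Among the measured compounds shown here, the measured steps only trade one aryl substituent of the benzyl for another; none of them removes the benzyl itself or brings in a thiourea, so no measured step bears directly on the change from compound 3 to compound 4. Those steps were all within the scatter, which argues against expecting a large move in this assay, but the lack of a precedent for this kind of change leaves the range wide.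

For compound 4 the estimate in this assay is 16000 nM, with a range from 3500 nM to 70000 nM. The step expected from compound 3 to compound 4 is a 1.2-fold lower number from compound 3 to compound 4 (0.07 log units; within the scatter).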

Compound 4, half-maximal inhibitory concentration: 15600 nM
The estimate for compound 4 lay 1.0-fold (0.01 log units) above the measured number, and the stated range covers the measured number.
By their numbers in this assay, from the lowest: compounds 1, 2, 4 and 3 (each within the scatter of the next).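

In this assay, the thiourea group of compound 4 on the amine nitrogen in a ring gives a 1.2-fold lower number from compound 3 to compound 4 (0.08 log units; within the scatter) and, against the other two benzyl compounds, a 1.2-fold higher number from compound 2 to compound 4 (0.08 log units; within the scatter) and a 1.6-fold higher number from compound 1 to compound 4 (0.22 log units; within the scatter) so that all three comparisons stay within the scatter. The earlier steps shown here only exchanged one substituted benzyl for another, whereas this one replaces the whole benzyl group and brings in a double bond outside aromatic rings, 1 hydrogen-bond donor and 1 hydrogen-bond acceptor, and the number still cannot be told apart from those of compounds 1, 2 and 3. No evidence is available to explain this result.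

With all four compounds within the scatter of one another, nothing yet shows that the group at this position can move the number in this assay at all, and every value remains weak on the scale of the read-out. Going by these compounds, whether a urea with oxygen in place of the sulfur, an acetyl group, a longer chain ending in a carboxylic acid or a free ring amine would give a step beyond the scatter remains open.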